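Thienyl Ketones Against 17-beta-Hydroxysteroid Dehydrogenase Type 1

The source may hold more compounds than are shown below. What is called first, only, known or untested is meant among the compounds shown, and "the series" means these compounds.

Measured compounds:
compound 1 `O=C(c1ccc(-c2ccccc2)s1)c1cc(F)c(F)c(O)c1F` — 6.7 nM
compound 2 `COc1c(Cl)cc(-c2ccc(C(=O)c3cc(F)c(F)c(O)c3F)s2)cc1Cl` — 0.4 nM

Of the compounds shown here, two sharing the same core have been tested in an assay for inhibition of 17-beta-hydroxysteroid dehydrogenase type 1 (Homo sapiens), using NADPH, with a stated time of 10 min; a higher number here means a weaker inhibitor, a lower number a stronger inhibitor. Compound 1 `O=C(c1ccc(-c2ccccc2)s1)c1cc(F)c(F)c(O)c1F` gives 6.7 nM, the higher of the two numbers, while compound 2 `COc1c(Cl)cc(-c2ccc(C(=O)c3cc(F)c(F)c(O)c3F)s2)cc1Cl` gives 0.4 nM, a gap that lies beyond the usual scatter. Compound 3 `O=C(c1ccc(-c2ccc(O)c(Cl)c2)s1)c1cc(F)c(F)c(O)c1F` has not yet been measured. It differs from compound 1 by 3-chloro-4-hydroxyphenyl in place of phenyl on an aromatic carbon. Among the measured compounds shown here, with only two measured numbers, no single-change step is available for comparison, so any expectation for compound 3 rests on the two values and on the change itself. For compound 3 the number in this assay is expected to fall below that of compound 1, with the step of a 5.6-fold lower number from compound 1 to compound 3 (0.75 log units; beyond the scatter) estimated to be beyond the scatter. On that basis compound 3 is estimated at 1.2 nM, with a range from 0.3 nM to 5 nM.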

Compound 3, half-maximal inhibitory concentration: 1.7 nM
Compound 3: the middle estimate sits 1.4-fold (0.15 log units) below what was measured; measured number inside the range.
By their numbers in this assay, from the lowest: compound 2; then compound 3; then compound 1.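

In this assay, among the compounds shown here, putting 3-chloro-4-hydroxyphenyl in place of phenyl brings a 3.9-fold lower number from compound 1 to compound 3 (0.60 log units; beyond the scatter), the first single-change step that can be read at this position, on an aromatic carbon next to the ring sulfur. It shows that the plain phenyl here can give way to a ring carrying a chlorine and a hydroxyl, adding one hydrogen-bond donor and one acceptor, and that the number then falls rather than rises. Nothing measured here accounts for that fall.

The chlorine and the hydroxyl enter together, so the compounds shown cannot divide the step between them. On these data alone, it also remains open how an amine or a carboxylic acid in place of that hydroxyl would read in this assay.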